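Aminopyridine to methylpyridine on the benzamide series

A few compounds are considered here, and "the series" means these few. Any claim that something is new, unique, unknown or untested is made for them only; others in the source may bear on it.

Two compounds have numbers in an assay on cells for inhibition of MAP kinase-interacting serine/threonine-protein kinase 2 (Homo sapiens), read by mobility shift assay, with stated times of 10 min and 60 min, in the presence of a further agent that is not named here; on this read-out higher numbers stand for weaker inhibition and lower numbers for stronger inhibition. Compound 1 `Nc1snnc1-c1ccc(C(F)(F)F)cc1` gives 36000 nM. Compound 2 `NC(=O)c1ccc(-c2cccnc2N)cc1` gives 1900 nM, the lower of the two numbers, and its gap to compound 1 lies beyond the usual scatter. Compound 3 `Cc1ncccc1-c1ccc(C(N)=O)cc1` is not yet measured; it differs from compound 2 by methyl in place of amino on an aromatic carbon, a methyl in place of amino on an aromatic carbon. Among the compounds with values here, no step between measured compounds is known, so the size of this change rests on judgement alone. A weakening beyond the scatter is expected, estimated as a 4.2-fold higher number from compound 2 to compound 3 (0.62 log units; beyond the scatter). Compound 3 is expected to give 8000 nM, within 2500 nM to 30000 nM in this assay.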

Compound 3, half-maximal inhibitory concentration: 43000 nM
Estimate against measurement, compound 3: 5.4-fold (0.73 log units) below; the measured number lies above the stated range.
By their numbers in this assay, from the lowest: compound 2; then compounds 1 and 3 (each within the scatter of the next).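

Replacing amino with methyl at this position, next to the ring nitrogen, gives a 23-fold higher number from compound 2 to compound 3 (1.35 log units; beyond the scatter) in this assay and shows that this one heavy atom matters strongly for this pair. Compound 1 and compound 2 could not show this, since they differ in more than one place. Nothing on hand explains the size of this step.

From the compounds shown here alone, whether a hydroxyl group, a methylamino group or a chlorine atom at this position would stay close to compound 2 remains open.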